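Replacing chloro with carbamoyl in compound 1

The source may report more compounds than this note shows. Statements on the series, on what has been measured and on what is new or still open speak of the compounds shown alone.

compound 1 `Cc1nc(-c2ccccc2)c(C(=O)N2CCN(c3cccc(Cl)c3)CC2)o1` gives 39.2 nM
compound 2 `Cc1nc(-c2cccc(F)c2)c(C(=O)N2CCN(c3cccc(Cl)c3)CC2)o1` gives 33.7 nM

Among the compounds with values here, the only measured step is a 1.2-fold lower number from compound 1 to compound 2 (0.07 log units; within the scatter) in a functional assay on HL-60 cells (Homo sapiens) for inhibition, read by MTT assay, with a stated time of 72 h (on this read-out lower numbers stand for stronger inhibition and higher numbers for weaker inhibition), and so compound 1 has no clear place above or below compound 2. Compound 3 `Cc1nc(-c2ccccc2)c(C(=O)N2CCN(c3cccc(C(N)=O)c3)CC2)o1` keeps the core of compound 1 and differs by carbamoyl in place of chloro on an aromatic carbon in one place, with 3-chlorophenyl becoming 3-carbamoylphenyl. The fluoro step lies elsewhere in the molecule and stayed within the scatter, so it says little about this exchange. Within the data shown here, no measured step covers carbamoyl in place of chloro. A shift towards a higher number in this assay is nevertheless expected, though its size is uncertain. The expected change is a 6.4-fold higher number from compound 1 to compound 3 (0.80 log units; beyond the scatter) with wide uncertainty. For compound 3 the estimated value is 250 nM with a range from 50 nM to 2000 nM as the expected bounds.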

Compound 3, half-maximal inhibitory concentration: 71 nM
Estimate against measurement, compound 3: 3.5-fold (0.55 log units) above; the range from low to high includes it.
By their numbers in this assay, from the lowest: compounds 2, 1 and 3 (each within the scatter of the next, the first and the last beyond it).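

Where the fluoro step lay elsewhere in the molecule, compound 3 changes the 3-chlorophenyl group itself. In this assay, carbamoyl in place of chloro gives a 1.8-fold higher number from compound 1 to compound 3 (0.26 log units; within the scatter), so this place on the ring accepts a group carrying a hydrogen-bond donor and a hydrogen-bond acceptor, which chloro lacks, with no difference beyond the scatter. No measurement shown here explains why the exchange leaves the number within the scatter.

On these data alone, whether this tolerance extends to other groups at this place remains open, for example a carboxylic acid, an aminomethyl group or a nitrile. As far as these compounds go, it is also open whether the amide hydrogen matters, which a methyl group on the carbamoyl nitrogen would address.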